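Ester to Ketone on a Pyrimidine Hydrazide Series

This account rests on a few compounds, and the source may have more. Where it says the series, first, only, none or still open, it means among the compounds named here.

Measured so far:
- compound 1, `CCOC(=O)c1cnc(NN2C(=O)C=C(C)C2=O)nc1C(F)(F)F`: 2000 nM
- compound 2, `CCOC(=O)c1cnc(NN2C(=O)C=C(C)C2=O)nc1CC`: 400 nM

Compound 1 gives the highest of the two numbers in an assay on Jurkat cells for inhibition of nuclear factor NF-kappa-B complex (Homo sapiens), read by a luciferase reporter; on this read-out lower numbers stand for stronger inhibition and higher numbers for weaker inhibition; its nearest neighbour is compound 2, reached by a 5.0-fold lower number from compound 1 to compound 2 (0.70 log units; beyond the scatter), a change of ethyl in place of trifluoromethyl on an aromatic carbon. Compound 3, `CC(=O)c1cnc(NN2C(=O)C=C(C)C2=O)nc1C(F)(F)F`, differs from compound 1 in another place: methyl in place of ethoxy on a carbonyl carbon, which cut one bond further out reads ethoxycarbonyl to acetyl. Within the data shown here, no measured step touches this carbonyl substituent; the single step, from compound 1 to compound 2, concerns the aromatic carbon only, so it gives no direction for the change in hand. Compound 3 is therefore expected to stay close to compound 1 in this assay, with no change at the digits printed from compound 1 to compound 3 (within the scatter) as the central guess and wide uncertainty. The estimate for compound 3 is 2000 nM, within 500 nM to 8000 nM.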

Compound 3, half-maximal inhibitory concentration: 4400 nM
Beside the measured number, compound 3's estimate is 2.2-fold (0.34 log units) below it; the measured number falls inside the stated range.
By their numbers in this assay, from the lowest: compound 2; then compound 1; then compound 3.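

In this assay, the group on the carbonyl carbon proves to be a place where the number responds: the change from ethoxycarbonyl to acetyl gives a 2.2-fold higher number from compound 1 to compound 3 (0.34 log units; beyond the scatter). With trifluoromethyl on the aromatic carbon, ethoxy therefore goes with stronger inhibition than methyl, a modest difference but one that lies beyond the scatter. Nothing available explains why this exchange weakens inhibition.

This single pair cannot show a trend with the size of the group on the carbonyl carbon, nor whether the same exchange would shift the number in the same direction with ethyl on the aromatic carbon, as in compound 2. As far as these compounds go, how a carboxylic acid, an amide or a longer chain such as propoxy would read at this carbonyl carbon also remains open.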